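From butyl to cyclopentyl on a sulfur

This account rests on a few compounds, and the source may have more. Where it says the series, first, only, none or still open, it means among the compounds named here.

Measured in an ADME assay on MT4 cells (Homo sapiens) for activation, read by MTT assay; a higher number here means that more compound is tolerated, a lower number that less compound is tolerated:
Compound 1 `CCCSc1nc(C(C)c2c(F)cccc2Cl)c(CC)c(=O)[nH]1` gives > 3000 nM
Compound 2 `CCCCSc1nc(C(C)c2c(F)cccc2Cl)c(CC)c(=O)[nH]1` gives > 3000 nM

Compound 2 stands at > 3000 nM, which is a limit and not a number. Compound 1 also gives only a limit, > 3000 nM. The evidence so far therefore comes down to one observation: the limit of > 3000 nM in this assay, at which 2 of the 2 values shown sit.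

Among the measured compounds shown here, the only measured step is a step that the two limits leave unreadable from compound 1 to compound 2. It places a methyl in place of hydrogen on a saturated chain carbon, three bonds along the chain from a sulfur, but it gives no size to build on.

Compound 3 `CCc1c(C(C)c2c(F)cccc2Cl)nc(SC2CCCC2)[nH]c1=O` has not yet been measured. Its change from compound 2 is cyclopentyl in place of butyl on a sulfur. With no readable step as a guide, no shift beyond the usual scatter, in either direction, is expected in this assay. The estimated size is a step that the limit leaves unreadable from compound 2 to compound 3. For compound 3 the expected value is 5000 nM, with an estimated range from 2000 nM to 20000 nM.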

Compound 3, half-maximal cytotoxic concentration: > 3000 nM
Compound 3: a limit, no number; the forecaster's own chance of this, stated with the estimate: 80%; the middle value does not contradict the limit.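

Compound 3 gives > 3000 nM in this assay, which is a limit and not a number. The steps to compound 3 from compound 1 and from compound 2 therefore cannot be read: the limit of > 3000 nM in this assay, at which 3 of the 3 values shown sit.

The compounds shown leave open how much of each is actually tolerated in this assay, and whether propyl, butyl or cyclopentyl on the sulfur makes any difference.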